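A few compounds are considered here, and "the series" means these few. Any claim that something is new, unique, unknown or untested is made for them only; others in the source may bear on it.

Of the compounds shown here, two have been tested in an ADME assay on a cell-free system (plasma, Homo sapiens) for metabolic stability, read by LC-MS, with a stated time of 60 min, at 37 degrees C, tested at 50 uM; on this read-out lower numbers stand for a less stable compound and higher numbers for a more stable compound. Compound 1, `C[C@@H](O)[C@H]1C(=O)N2C(C(=O)OCOC(=O)C(C)(C)C)=C(S[C@@H]3CN[C@H](C(=O)Nc4cccc(C(=O)O)c4)C3)[C@H](C)[C@H]12`, gives 45% in this assay. Going by the values given here, compound 2, `CCOC(=O)C1=C(S[C@H]2C[C@@H](C(=O)Nc3cccc(C(=O)OCC)c3)N(C(=O)OCc3oc(=O)oc3C)C2)[C@H](C)[C@@H]2[C@@H]([C@@H](C)O)C(=O)N12`, gives 9% in this assay, a number that lies beyond the scatter below that of compound 1; compound 1 therefore stands highest of the two numbers known. Among the compounds with values here, the two compounds differ in several places at once, so no single step between them can be read from their values.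

Compound 3, `CCC(CC)C(=O)OCOC(=O)C1=C(S[C@@H]2CN[C@H](C(=O)Nc3cccc(C(=O)O)c3)C2)[C@H](C)[C@@H]2[C@@H]([C@@H](C)O)C(=O)N12`, differs from compound 1 in one place only: pentan-3-yl in place of tert-butyl on a carbonyl carbon. Within the data shown here, no measured pair in this set shows a change of this kind, so no step can be taken from the data. The change is a small one on an ester remote from most of the molecule, and no step beyond the scatter is expected from compound 1 to compound 3, though a slight drift downward is not excluded. Compound 3 is therefore estimated to give 40% in this assay, within a range of 25% to 55%, an expected step of a number 5 percentage points lower from compound 1 to compound 3 (within the scatter).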

Compound 3, percent of the compound remaining: 82%
For compound 3 the middle estimate is 42 percentage points below the measured one; the whole stated range lies below it.
By their numbers in this assay, from the lowest: compound 2; then compound 1; then compound 3.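

In this assay, putting pentan-3-yl in place of tert-butyl on a carbonyl carbon, whose other neighbours are an oxygen next to a carbonyl group, gives a large step, a number 37 percentage points higher from compound 1 to compound 3 (beyond the scatter). Going by these compounds alone, this is the first pair that differs in one place only, and it shows that the read-out can respond strongly at this position, even though the group that leaves has 4 heavy atoms, the group that enters has 5, and neither carries a ring, a hydrogen-bond donor or acceptor, or a net charge. Within the data shown here, nothing available explains why so small an exchange moves the number so far.

On these data alone, it remains open whether this rise belongs to pentan-3-yl alone or would also appear with other groups at this place, such as isopropyl, a cyclohexyl ring, a longer chain like heptan-4-yl, or a chain carrying an amine. As far as these compounds go, it also remains open whether the same exchange would give a step of similar size on a compound that differs from compound 1 elsewhere in the molecule.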